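From hydroxy to methoxy on compound 1

This account rests on a few compounds, and the source may have more. Where it says the series, first, only, none or still open, it means among the compounds named here.

Among the measured compounds shown here, in a functional assay on SW-620 cells (Homo sapiens) for antiproliferative activity, read by sulforhodamine B assay, with a stated time of 48 h (a lower number here means a stronger inhibitor, a higher number a weaker inhibitor), compound 1 `O=C(CCCCCCN1C(=O)/C(=N\O)c2cc([N+](=O)[O-])ccc21)NO` gives 3390 nM, the higher of the two numbers measured so far. Compound 2 `Cc1ccc2c(c1)/C(=N/O)C(=O)N2CCCCCCC(=O)NO` gives 990 nM. Compound 3 `CO/N=C1\C(=O)N(CCCCCCC(=O)NO)c2ccc([N+](=O)[O-])cc21` keeps the core of compound 1 but turns hydroxy into methoxy: methyl in place of hydrogen on an oxygen. For the measured compounds named here, the only measured step, a 3.4-fold lower number from compound 1 to compound 2 (0.53 log units; beyond the scatter), puts methyl in place of nitro on an aromatic carbon. It is a modest change beyond the scatter, but it involves a different group. Going by the values given here, no measured step touches this oxygen, so the data suggest no direction and offer only a rough guide to size. In this assay, no change beyond the scatter is therefore expected. The expected step is a 1.1-fold lower number from compound 1 to compound 3 (0.05 log units; within the scatter). For compound 3 the estimated value is 3000 nM, with an expected range from 1200 nM to 7500 nM.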

Compound 3, half-maximal inhibitory concentration: 1350 nM
The estimate for compound 3 lay 2.2-fold (0.35 log units) above the measured number; measured number inside the range.
By their numbers in this assay, from the lowest: compounds 2 and 3 (each within the scatter of the next); then compound 1.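

Methyl in place of hydrogen on this oxygen gives a 2.5-fold lower number from compound 1 to compound 3 (0.40 log units; beyond the scatter) in this assay. Among the compounds shown here, this is the first measured change at this oxygen, and it shows that the position responds to a small change, even though the step is modest. It also shows that the hydrogen on this oxygen is not needed for activity in this assay, since the methoxy compound, compound 3, gives the lower number. Nothing shown here explains why the number falls.

The compounds shown leave open whether a larger group on this oxygen, such as ethyl or benzyl, would carry the trend further or reverse it. From the compounds shown here alone, it also remains open whether methoxy would give a similar step on the core of compound 2, which carries methyl where compound 1 carries nitro.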